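The compounds below may be only part of what the source reports. "The series", "measured", "known", "first", "only" and "open" are said of these compounds alone.

Compound 1 `COc1ncnc2c1c(-c1ccsc1)cn2[C@@H]1O[C@H](CO)[C@@H](O)[C@H]1O` carries a methoxy group and a thiophen-3-yl group on its core. In a functional assay on HepG2 cells (Homo sapiens) for antiproliferative activity, read by XTT assay, with a stated time of 72 h (on this read-out lower numbers stand for stronger inhibition and higher numbers for weaker inhibition), compound 1 gives 430 nM, the only number shown here. Compound 2 `CNc1ncnc2c1c(-c1ccsc1)cn2[C@@H]1O[C@H](CO)[C@@H](O)[C@H]1O` gives only a limit, > 20000 nM, in this assay. The step of an at least 46-fold higher number from compound 1 to compound 2 (1.66 log units; beyond the scatter) concerns the methylamino group alone and does not touch the thiophen-3-yl group. Among the compounds with values here, compound 3 `COc1ncnc2c1c(-c1ccco1)cn2[C@@H]1O[C@H](CO)[C@@H](O)[C@H]1O` differs from compound 1 by furan-2-yl in place of thiophen-3-yl on an aromatic carbon, a change for which no measured step exists. For compound 3 the expected step is a 1.5-fold higher number from compound 1 to compound 3 (0.18 log units; within the scatter), within the scatter. Compound 3 is therefore estimated at 650 nM, between 150 nM and 3000 nM.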

Compound 3, half-maximal inhibitory concentration: 300 nM
For compound 3 the middle estimate is 2.2-fold (0.34 log units) above the measured one, and the stated range covers the measured number.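

Putting furan-2-yl in place of thiophen-3-yl gives a 1.4-fold lower number from compound 1 to compound 3 (0.16 log units; within the scatter) in this assay. This position therefore takes either of these two five-membered aromatic rings, one with sulfur and one with oxygen, with no difference beyond the scatter. Nothing measured here bears on why the two rings match.

From the compounds shown here alone, whether a phenyl ring, an open alkyl chain or an amine would fit this position equally well remains open. So does what furan-2-yl would give with methylamino in place of methoxy.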